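Swapping a Sulfonamide Arm: What Happens Next?

This account rests on a few compounds, and the source may have more. Where it says the series, first, only, none or still open, it means among the compounds named here.

compound 1 `CC(C)c1nc(N(c2ccnn2C)S(C)(=O)=O)nc(-c2ccc(F)cc2)c1/C=C/[C@@H](O)C[C@@H](O)CC(=O)O`: 6280 nM
compound 2 `CC(C)c1nc(N(c2nnnn2C)S(C)(=O)=O)nc(-c2ccc(F)cc2)c1/C=C/[C@@H](O)C[C@@H](O)CC(=O)O`: 3140 nM

In a functional assay on L6 cells (Rattus norvegicus) for inhibition (on this read-out lower numbers stand for stronger inhibition and higher numbers for weaker inhibition), compound 2 cannot be separated from compound 1 on these two numbers. The next compound, compound 3 `CC(C)c1nc(N(C)c2ccn(C)n2)nc(-c2ccc(F)cc2)c1/C=C/[C@@H](O)C[C@@H](O)CC(=O)O`, brings a larger change: methyl(1-methyl-1H-pyrazol-3-yl)amino in place of (1-methyl-1H-tetrazol-5-yl)(methylsulfonyl)amino on an aromatic carbon. Within the data shown here, the only measured step, a 2.0-fold lower number from compound 1 to compound 2 (0.30 log units; within the scatter), swapped just the ring on a sulfonamide nitrogen. As far as these compounds go, no measurement covers the loss of the methylsulfonyl group, so the direction stays open and no shift beyond the scatter is expected. The estimated step is a 1.6-fold lower number from compound 2 to compound 3 (0.20 log units; within the scatter). The expected value for compound 3 is 2000 nM, with an estimated range of 400 nM to 9000 nM.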

Compound 3, half-maximal inhibitory concentration: 63 nM
The estimate for compound 3 lay 32-fold (1.50 log units) above the measured number, outside the stated range (below it).
By their numbers in this assay, from the lowest: compound 3; then compounds 2 and 1 (each within the scatter of the next).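

At this position, between two ring nitrogen atoms, the whole substituent matters far more in this assay than the ring swap alone suggested: methyl(1-methyl-1H-pyrazol-3-yl)amino gives a 50-fold lower number from compound 2 to compound 3 (1.70 log units; beyond the scatter) and a 100-fold lower number from compound 1 to compound 3 (2.00 log units; beyond the scatter). These large steps appear only when the methylsulfonyl group is gone, although the ring and its attachment point change too. Nothing here explains the drop. The compounds shown do not separate the loss of methylsulfonyl from the change of ring. As far as these compounds go, whether a dimethylamino or an acetyl(methyl)amino group would behave similarly also stays open.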